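Two chlorines give way to two fluorines on the aryl ketone

The compounds below may be only part of what the source reports. "The series", "measured", "known", "first", "only" and "open" are said of these compounds alone.

Measured compounds:
- compound 1, `COc1ccc(-c2cc(/C=C/C(=O)c3ccc(OC)c(OC)c3)[nH]n2)cc1`: 1650 nM
- compound 2, `COc1cc(-c2cc(/C=C/C(=O)c3ccc(Cl)c(Cl)c3)[nH]n2)cc(OC)c1OC`: 18500 nM
- compound 3, `COc1cc(C(=O)/C=C/c2cc(-c3cc(OC)c(OC)c(OC)c3)n[nH]2)cc(OC)c1OC`: 1820 nM

In a functional assay on SK-MEL-28 cells (Homo sapiens) for inhibition, read by sulforhodamine B assay, with a stated time of 48 h (a lower number here means a stronger inhibitor of growth, a higher number a weaker inhibitor of growth), compound 2 gives 18500 nM, the highest of the three numbers. Both neighbours lie well below it and the gaps are beyond the scatter: in this assay compound 3 gives 1820 nM and compound 1 gives 1650 nM. Compound 2 is therefore the weakest growth inhibitor of the three.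

Compound 4, `COc1cc(-c2cc(/C=C/C(=O)c3ccc(F)c(F)c3)[nH]n2)cc(OC)c1OC`, has not yet been measured. It differs from compound 2 in one place: 3,4-difluorophenyl in place of 3,4-dichlorophenyl on a carbonyl carbon. Within the data shown here, no step between two measured compounds maps onto this exchange, so nothing in the set fixes its size or direction. The two better compounds carry methoxy-bearing aryl ketones rather than halogenated ones, but neither is a one-change partner of compound 4.

Compound 4 is expected to stay close to compound 2, with a small downward step, a 1.9-fold lower number from compound 2 to compound 4 (0.27 log units; within the scatter), not beyond the scatter. The estimate for compound 4 in this assay is 10000 nM, within 3000 nM to 35000 nM.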

Compound 4, concentration for 50% growth inhibition: 5310 nM
For compound 4 the middle estimate is 1.9-fold (0.27 log units) above the measured one; low and high end bracket the measured number.
By their numbers in this assay, from the lowest: compounds 1 and 3 (each within the scatter of the next); then compound 4; then compound 2.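

Among these compounds, the exchange gives the first one-change step at this position: on a carbonyl carbon, 3,4-difluorophenyl in place of 3,4-dichlorophenyl gives a 3.5-fold lower number from compound 2 to compound 4 (0.54 log units; beyond the scatter) in this assay, a modest gain in growth inhibition. The read-out therefore responds to the identity of the halogen here, even though the two groups match in heavy atoms, hydrogen-bond donors and acceptors, and net charge. Nothing at hand explains the size or direction of this step.

Still open, on these data alone, is whether the gain would continue with a single fluorine, or how a trifluoromethyl, a nitrile or an amine on this aryl ketone would compare. As far as these compounds go, it is also open whether the same exchange would give a similar step on the core of compound 1.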